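Benzamide series, HCC78 antiproliferative: aminoheteroaryl swap

The source may hold more compounds than are shown below. What is called first, only, known or untested is meant among the compounds shown, and "the series" means these compounds.

Measured so far:
compound 1 `Cc1ccc(CNC(=O)c2cccc(C(C)Oc3cccnc3Nc3cnn(CC(C)(C)O)c3)c2)cc1` — 20500 nM
compound 2 `Cc1ccc(CNC(=O)c2cccc(C(C)Oc3ccnc(Nc4cn(C)nc4C)c3)c2)cc1` — 17500 nM

Both compounds have been run in a functional assay on HCC78 cells (Homo sapiens) for antiproliferative activity, read by MTT assay, with a stated time of 48 h; a lower number here means a stronger inhibitor, a higher number a weaker inhibitor. Compound 1 gives 20500 nM. Compound 2 gives 17500 nM, the lower of the two numbers, but the gap to compound 1 is within the scatter of this assay, so the two cannot be told apart. Among the compounds with values here, no pair differing in one place has been measured, so no step size is established.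

Compound 3 `Cc1ccc(CNC(=O)c2cccc(C(C)Oc3ccnc(Nc4nc5ccccc5[nH]4)c3)c2)cc1` is not yet measured. It differs from compound 2 in one place: 1H-benzimidazol-2-yl in place of 1,3-dimethyl-1H-pyrazol-4-yl on a nitrogen on an aromatic ring. Within the data shown here, no measured step bears on this change, so the expectation rests only on the numbers for compound 2 and compound 1, which sit close together. For compound 3 the step of a 1.5-fold lower number from compound 2 to compound 3 (0.16 log units; within the scatter) is expected to be small, a slight lowering at most, and not clearly beyond the scatter. The estimate for compound 3 in this assay is 12000 nM, with a range from 3000 nM to 40000 nM.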

Compound 3, half-maximal inhibitory concentration: > 100000 nM
Compound 3 gave a limit, no number; the forecaster's own chance of this, stated with the estimate: 10%; at least 8.3-fold (0.92 log units) between middle value and limit.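

Within the data shown here, the change from (1,3-dimethyl-1H-pyrazol-4-yl)amino to (1H-benzimidazol-2-yl)amino gives the only step in this assay that can be read so far, an at least 5.7-fold higher number from compound 2 to compound 3 (0.75 log units; beyond the scatter), and it shows that activity in this assay depends on the group carried on this nitrogen, which the earlier values, with no step among them, could not show. The change adds a six-membered aromatic ring of carbon only and a hydrogen-bond donor together, so this single pair ties the loss to the whole swap and not to either feature alone. Compound 3 stands at a limit of the assay, so the step gives only a minimum and not a true size: the limit of > 100000 nM in this assay, at which 1 of the 3 values shown sits.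

Which feature of the swap carries the loss remains open: a 1H-imidazol-2-yl group would keep the donor without the carbon ring, and a 1-methyl-1H-benzimidazol-2-yl group would keep the carbon ring without the donor. Also open, on these data alone, is whether any group on this nitrogen moves the number below that of compound 2 17500 nM, for example a simple 1-methyl-1H-pyrazol-4-yl or a pyridin-3-yl group.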